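A few compounds are considered here, and "the series" means these few. Any claim that something is new, unique, unknown or untested is made for them only; others in the source may bear on it.

In a functional assay on A549 cells (Homo sapiens) for antiproliferative activity, read by MTT assay, with a stated time of 48 h (a higher number here means a weaker inhibitor, a lower number a stronger inhibitor), two compounds built on a shared core have been examined. Compound 1, `Cc1ccc(-n2nncc2CN2C(=O)C3(C(C#N)=C(N)Oc4c3c3nc5ccccc5nc3c3ccccc43)c3ccccc32)c(C)c1`, is one of them; in this assay compound 1 gives > 50000 nM, a limit of the assay rather than a number, and the limit of > 50000 nM in this assay, at which 1 of the 2 values shown sits, marks where that value sits. Going by the values given here, compound 2, `N#CC1=C(N)Oc2c(N)cc3nc4ccccc4nc3c2C12C(=O)N(Cc1cnnn1-c1ccccc1Br)c1ccccc12`, carries a 2-bromophenyl on an aromatic nitrogen, and in this assay compound 2 gives 27400 nM, the only true number among the values shown. Compound 3, `N#CC1=C(N)Oc2c(N)cc3nc4ccccc4nc3c2C12C(=O)N(Cc1cnnn1-c1ccc(Cl)cc1[N+](=O)[O-])c1ccccc12`, has not yet been measured; it differs from compound 2 by 4-chloro-2-nitrophenyl in place of 2-bromophenyl on an aromatic nitrogen. Among the compounds with values here, no step between two measured compounds differing in a single place has been recorded, so there is no measured change to guide the reading. With that gap in mind, the expected step of a 1.1-fold lower number from compound 2 to compound 3 (0.04 log units; within the scatter) is one that stays within the usual scatter, in no set direction. Compound 3 is therefore estimated to give 25000 nM in this assay, with a range from 8000 nM to 60000 nM.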

Compound 3, half-maximal inhibitory concentration: > 50000 nM
Compound 3: a limit, no number (the forecaster's own chance of this, stated with the estimate: 30%); middle value at least 2.0-fold (0.30 log units) from the limit.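

In this assay, going by these compounds alone, 4-chloro-2-nitrophenyl in place of 2-bromophenyl on the aromatic nitrogen gives an at least 1.8-fold higher number from compound 2 to compound 3 (0.26 log units; that floor lies within the scatter), the first step that can be read at this position. The value of compound 3 is a limit of the assay and not a number, so this step is only a floor: it shows no sign of a lower number with this change, but that floor does not separate compound 3 from compound 2 beyond the usual scatter. Compound 2 therefore remains the only compound shown with a true number, and the real size of the step cannot be read: the limit of > 50000 nM in this assay, at which 2 of the 3 values shown sit.

The compounds shown leave open whether the chlorine or the nitro group accounts for the step, since 4-chlorophenyl and 2-nitrophenyl do not appear among them as separate changes. They also leave open how a plain phenyl, or a phenyl carrying an amine or a carboxylic acid, would read at this position on the same core.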